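The source may report more compounds than this note shows. Statements on the series, on what has been measured and on what is new or still open speak of the compounds shown alone.

Measured in an ADME assay (liver) for metabolic stability, with Liver microsome (Canis lupus familiaris) as the target, read by LC-MS, using microsomes, with a stated time of 30 min, tested at 4 uM; a higher number here means that more of the compound is left, a lower number that less of the compound is left:
- Compound 1 `COCCn1c(-c2ccccc2Cl)nc2c(N3CCN(C(C)=O)CC3)nc(C)nc21`: 34%
- Compound 2 `Cc1nc(N2CCN(C)CC2)c2nc(-c3ccccc3C(F)(F)F)n(C3CCOCC3)c2n1`: 61%

Compound 2 stands highest of these two, and its gap to compound 1 lies beyond the scatter. Compound 3 `COc1ccccc1-c1nc2c(N3CCN(C)CC3)nc(C)nc2n1C1CCOCC1` has methoxy in place of trifluoromethyl on an aromatic carbon, ortho to a large group, compared with compound 2 (methoxy in place of trifluoromethyl on an aromatic carbon). Within the data shown here, no measured pair shows this change, so the expectation starts from compound 2 at 61% and stays loose. A modest fall of a number 11 percentage points lower from compound 2 to compound 3 (beyond the scatter) is expected in this assay. For compound 3 the estimated value is 50%, within an expected range of 30% to 72%.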

Compound 3, percent of the compound remaining: 36%
Estimate against measurement, compound 3: 14 percentage points above; low and high end bracket the measured number.
By their numbers in this assay, from the lowest: compounds 1 and 3 (each within the scatter of the next); then compound 2.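

This pair isolates a single group on an aromatic carbon, ortho to a large group. In this assay, methoxy in place of trifluoromethyl gives a number 25 percentage points lower from compound 2 to compound 3 (beyond the scatter), so what sits at this position matters to how much compound is left. Nothing measured here explains why the number moves.

On these data alone, this is one swap on one core, so it remains open how a fluorine or a nitrile at this position would compare. As far as these compounds go, whether the same swap gives a similar step with other groups elsewhere on the core also remains open.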